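The source may hold more compounds than are shown below. What is called first, only, known or untested is meant among the compounds shown, and "the series" means these compounds.

Of the compounds shown here, two have been measured in a functional assay on NCI/ADR cells (Homo sapiens) for inhibition, read by sulforhodamine B assay, with a stated time of 48 h (on this read-out lower numbers stand for stronger inhibition of growth and higher numbers for weaker inhibition of growth), so far. Compound 1 `O=c1ccoc(/C=C/c2ccccc2)c1` gives 514 uM in this assay. Compound 2 `O=C1C=CCC(/C=C/c2ccc(C(F)(F)F)cc2)O1` gives 54.8 uM in this assay, the lowest of the two numbers shown, and the gap to compound 1 lies beyond the usual scatter of repeated measurements. The two cores differ, so only the two values themselves can be compared.

The next compound, compound 3 `COc1ccc(/C=C/C2CC=CC(=O)O2)cc1`, keeps the core of compound 2 and differs from it in one place: methoxy in place of trifluoromethyl on an aromatic carbon. The new group sits on an aromatic carbon of a six-membered aromatic ring of carbon only. For the measured compounds named here, no measured pair in this set shows what such an exchange does, so the size of the step is uncertain; a modest step in this assay, if any, toward a somewhat higher number is expected, and the expected step from compound 2 to compound 3 is a 1.5-fold higher number from compound 2 to compound 3 (0.16 log units; within the scatter). Compound 3 is therefore estimated at 80 uM in this assay, with a range from 25 uM to 250 uM.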

Compound 3, concentration for growth inhibition (reported as GI): 17.3 uM
Compound 3: the middle estimate sits 4.6-fold (0.67 log units) above what was measured; the measured number lies below the stated range.
By their numbers in this assay, from the lowest: compound 3; then compound 2; then compound 1.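

In this assay, for the compounds shown here, methoxy in place of trifluoromethyl on an aromatic carbon, para to a group of 9 heavy atoms, gives a 3.2-fold lower number from compound 2 to compound 3 (0.50 log units; beyond the scatter) and provides the first measured exchange at this position. The number here therefore changes beyond the usual scatter with the group carried at this position on the shared core, and the entering methoxy has fewer heavy atoms and one more hydrogen-bond acceptor than the trifluoromethyl it replaces, although a single pair sets no trend. Nothing measured for these compounds explains the step.

The compounds shown leave open whether another group at this position, such as an amine, a hydroxyl or a longer alkoxy chain, would lower the number further. They also leave open whether methoxy would have a similar effect at another position on the ring or on the core of compound 1.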